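A Hydroxycyclobutylmethyl Amine Swapped for Methoxycyclohexyl

The compounds below may be only part of what the source reports. "The series", "measured", "known", "first", "only" and "open" are said of these compounds alone.

Compound 1 `N#Cc1cnc(NCc2cnccc2C(F)(F)F)cc1NC[C@H]1C[C@@H](O)C1` and compound 2 `N#Cc1cnc(NCc2cnccc2C(F)(F)F)cc1NC[C@H]1C[C@H](O)C1` share every atom and bond and differ only in configuration as drawn. In an assay on isolated protein for inhibition of protein kinase C delta type (Homo sapiens), read by TR-FRET, with a stated time of 2 h (on this read-out higher numbers stand for weaker inhibition and lower numbers for stronger inhibition), compound 1 gives 4200 nM. For compound 2 this assay returns only a limit, > 10000 nM. The step of an at least 2.3-fold higher number from compound 1 to compound 2 (0.37 log units; beyond the scatter) therefore rests on a limit on one side, as the limit of > 10000 nM in this assay, at which 1 of the 2 values shown sits, records, and on a change of configuration alone, as the fact that compounds 1 and 2 differ only in the configuration as drawn records. Compound 2 thus stands at the weak end of the two values shown, without a number of its own.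

Compound 3 `CO[C@H]1CC[C@@H](Nc2cc(NCc3cnccc3C(F)(F)F)ncc2C#N)CC1` has not yet been measured. It differs from compound 2 by 4-methoxycyclohexyl in place of (3-hydroxycyclobutyl)methyl on a nitrogen on an aromatic ring. For the measured compounds named here, no measured step involves such a replacement of the group on that nitrogen; the single step available concerns configuration only, so it offers no direct guide to this change, and the direction remains open. Given that compound 2 sits at a limit, the step to compound 3 is estimated as an at least 3.3-fold lower number from compound 2 to compound 3 (0.52 log units; beyond the scatter). Compound 3 is expected to fall at about 3000 nM, within a range from 500 nM to 20000 nM, with a real chance that this assay again reports only a limit.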

Compound 3, half-maximal inhibitory concentration: 5000 nM
Compound 3: middle estimate off by 1.7-fold (0.22 log units), on the low side, and the stated range covers the measured number.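

In this assay compound 3 returns a number rather than a limit, which shows that this nitrogen on an aromatic ring can carry a six-membered carbon ring attached directly, in place of the four-membered ring held on a methyl link, and still give a measurable reading. The change reads a 1.2-fold higher number from compound 1 to compound 3 (0.08 log units; within the scatter), so (4-methoxycyclohexyl)amino and ((3-hydroxycyclobutyl)methyl)amino in the configuration as drawn in the first of these compounds cannot be told apart here, even though the entering group counts 0 hydrogen-bond donors and the leaving group counts 1. The other reading, an at least 2.0-fold lower number from compound 2 to compound 3 (0.30 log units; that floor lies within the scatter), starts from a limit and gives no size beyond that floor: the limit of > 10000 nM in this assay, at which 1 of the 3 values shown sits.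

It stays open what the opposite configuration of the 4-methoxycyclohexyl group would give in this assay, since the only configurational comparison shown concerns the cyclobutyl pair. As far as these compounds go, it also stays open whether the methoxy group matters at all, a question that a 4-hydroxycyclohexyl or a 4-aminocyclohexyl group on the same nitrogen would address.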